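A few compounds are considered here, and "the series" means these few. Any claim that something is new, unique, unknown or untested is made for them only; others in the source may bear on it.

Measured so far:
compound 1, `O=C(O)CCCSCCN1C(=O)OC[C@@H]1/C=C/[C@@H](O)Cc1cccc(C(F)(F)F)c1` — in a functional assay on CHO cells for agonist activity at prostaglandin E2 receptor EP4 subtype (Rattus norvegicus), read by cAMP accumulation and immunoassay, with a stated time of 10 min (on this read-out higher numbers stand for an effect only at larger amounts of compound and lower numbers for an effect already at smaller amounts), compound 1 gives 12 nM
compound 2, `CCCc1cccc(C[C@H](O)/C=C/[C@H]2CSC(=O)N2CCSCCCC(=O)O)c1` — in this assay compound 2 gives 6.1 nM

Compound 1 and compound 2 share the same acid-bearing chain and the same unsaturated linker to the substituted phenyl ring; they differ in the ring of the core and in the group on the phenyl ring. Their two numbers lie within the usual scatter of repeated measurements of each other, so nothing separates them on this assay.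

Compound 3, `COCc1cccc(C[C@H](O)/C=C/[C@H]2COC(=O)N2CCSCCCC(=O)O)c1`, has not yet been measured. It keeps the core of compound 1 and differs from it only on the phenyl ring: methoxymethyl in place of trifluoromethyl on an aromatic carbon. Going by the values given here, no measured pair shows this particular exchange, so there is no directly comparable step to lean on.

With trifluoromethyl and propyl both giving low numbers in compound 1 and compound 2, the expectation is that methoxymethyl stays in a similar region, with a modest rise in the number, the step of a 2.5-fold higher number from compound 1 to compound 3 (0.40 log units; beyond the scatter) being the estimate. Compound 3 is thus expected to give about 30 nM, in the range from 6 nM to 150 nM.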

Compound 3, half-maximal effective concentration: 24 nM
Compound 3: middle estimate off by 1.3-fold (0.10 log units), on the high side, and the stated range covers the measured number.
By their numbers in this assay, from the lowest: compounds 2, 1 and 3 (each within the scatter of the next, the first and the last beyond it).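

Swapping trifluoromethyl for methoxymethyl in this assay gives a 2.0-fold higher number from compound 1 to compound 3 (0.30 log units; within the scatter), and this is the first comparison here in which only the group on the phenyl ring differs, since compound 1 and compound 2 differ in both the core and that group. On the core of compound 1, this position therefore accepts a group with oxygen and a hydrogen-bond acceptor in place of one with fluorine and no acceptor, with no separation between the two numbers on this read-out. No measurement presented here explains this result.

Going by these compounds, a single exchange at this position cannot show how far this holds, so it remains open whether an amine, a carboxylic acid or a longer chain in the same place would also give a number close to those of compound 1 and compound 3. The contribution of the core alone also remains open, as no two compounds shown differ only there, and a propyl group on the core of compound 1 would be needed to separate it.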